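Chloro-to-amino exchange on a fused bichloro core: notes

The source may report more compounds than this note shows. Statements on the series, on what has been measured and on what is new or still open speak of the compounds shown alone.

Measured so far, in a functional assay on HOP-62 cells (Homo sapiens) for cytotoxicity, read by sulforhodamine B assay, with a stated time of 48 h; on this read-out lower numbers stand for stronger inhibition of growth and higher numbers for weaker inhibition of growth:
compound 1, `Nc1nc(Cl)c2ncn(Cc3ccc(CCl)cc3)c2n1`, gives 27500 nM;
compound 2, `ClCc1cccc(Cn2cnc3c(Cl)nc(Cl)nc32)c1`, gives 4360 nM;
compound 3, `ClCc1ccc(Cn2cnc3c(Cl)nc(Cl)nc32)cc1`, gives 5130 nM.

Compound 2 and compound 3 have the same atoms joined differently; the difference between the two cores is not broken down here, and their two numbers in this assay sit within the usual scatter of each other. Compound 1 carries a higher number than either of them.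

One change is seen in a measured pair: from compound 3 to compound 1, (amino in place of chloro on an aromatic carbon). The step it made is a 5.4-fold higher number from compound 3 to compound 1 (0.73 log units; beyond the scatter).

Compound 4, `Nc1nc(Cl)c2ncn(Cc3cccc(CCl)c3)c2n1`, is not yet measured. It differs from compound 2 by amino in place of chloro on an aromatic carbon, the same change at the same kind of place, word for word, as in the measured pair. On that basis the step is expected to repeat in size, and compound 4 is expected to show a 5.0-fold higher number from compound 2 to compound 4 (0.70 log units; beyond the scatter) relative to compound 2, because compound 1 showed a 5.4-fold higher number from compound 3 to compound 1 (0.73 log units; beyond the scatter) over compound 3. The estimate for compound 4 is therefore 22000 nM, with a plausible range from 8000 nM to 60000 nM; it rests on a single precedent.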

Compound 4, concentration for total growth inhibition: 20400 nM
For compound 4 the middle estimate is 1.1-fold (0.03 log units) above the measured one, within the range that was stated.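

In this assay amino in place of chloro on an aromatic carbon gives a 4.7-fold higher number from compound 2 to compound 4 (0.67 log units; beyond the scatter) and thus moves the number in the weaker direction on a second core. Set beside the earlier step, the size of the change carries over from one core to the other:
the same change on two cores in this assay, a 5.4-fold higher number (0.73 log units; beyond the scatter) from compound 3 to compound 1 and a 4.7-fold higher number (0.67 log units; beyond the scatter) from compound 2 to compound 4, 1.1-fold (0.06 log units) apart, within the scatter of two such steps

This shows a repeatable step for these two pairs in this single cell read-out, but two pairs do not establish a rule for the series, do not show that the step would hold on a more different core, and give no reason for its size.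

The compounds shown leave open how other groups at the same aromatic carbon, such as methylamino, dimethylamino or methoxy, would compare with chloro and amino. They also leave open whether the same exchange behaves alike when the chloromethyl group is replaced by a hydroxymethyl group or a longer chain.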